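The source may report more compounds than this note shows. Statements on the series, on what has been measured and on what is new or still open speak of the compounds shown alone.

Three compounds share one core and differ only in the group carried on an amine nitrogen whose other neighbour is a saturated chain carbon. Compound 1 `CC(=O)NCCS(=O)(=O)NC(=O)c1ccc(Nc2nc(NC3(c4ccc(Cl)cc4)CC3)nc(OCC(F)(F)F)n2)cc1` carries acetyl there, and in an ADME assay on microsomes from liver (Rattus norvegicus) for metabolic stability, with a stated time of 10 min (a higher number here means that more of the compound is left, a lower number that less of the compound is left), compound 1 gives 100%. Compound 2 `CC(C)(C)CNCCS(=O)(=O)NC(=O)c1ccc(Nc2nc(NC3(c4ccc(Cl)cc4)CC3)nc(OCC(F)(F)F)n2)cc1` carries neopentyl, and in this assay compound 2 gives 90%. Compound 3 `O=C(NS(=O)(=O)CCNCc1ccccc1)c1ccc(Nc2nc(NC3(c4ccc(Cl)cc4)CC3)nc(OCC(F)(F)F)n2)cc1` carries benzyl, and in this assay compound 3 gives 100%, level with compound 1, the two together holding the highest numbers of the three. The steps among them were no change at the digits printed from compound 1 to compound 3 (within the scatter) and a number 10 percentage points higher from compound 2 to compound 3 (within the scatter), both within the scatter, as was a number 10 percentage points lower from compound 1 to compound 2 (within the scatter).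

Compound 4 `CC(C)NCCS(=O)(=O)NC(=O)c1ccc(Nc2nc(NC3(c4ccc(Cl)cc4)CC3)nc(OCC(F)(F)F)n2)cc1` is the next variation: isopropyl in place of benzyl on an amine nitrogen. The steps already measured exchange groups on the same nitrogen, and none of them moved the number beyond the scatter, so no step beyond the scatter is expected in this assay here either. For compound 4 the expected step is a number 5 percentage points lower from compound 3 to compound 4 (within the scatter). Compound 4 is therefore estimated at 95%, within a range from 80% to 100%.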

Compound 4, percent of the compound remaining in the liver assay: 100%
Compound 4: the middle estimate sits 5 percentage points below what was measured; the range from low to high includes it.
By their numbers in the liver assay, from the lowest: compounds 2, 1, 3 and 4 (each within the scatter of the next).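

In the liver assay, benzyl with its aromatic ring gives way to isopropyl, which has no ring, and the result is no change at the digits printed from compound 3 to compound 4 (within the scatter), so at this amine nitrogen the ring can go without the number leaving the scatter; the same holds for a number 10 percentage points higher from compound 2 to compound 4 (within the scatter) and no change at the digits printed from compound 1 to compound 4 (within the scatter). The exchange can now also be read in a physicochemical assay for permeability, using PAMPA, at pH 7.4 (on this read-out higher numbers stand for higher permeability and lower numbers for lower permeability), where compound 3 gives 49 nm/s and compound 4 gives 45 nm/s, which amounts to a 1.1-fold lower number from compound 3 to compound 4 (0.04 log units; within the scatter). The data offer no explanation for either result.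

From the compounds shown here alone, it stays open whether a hydroxyethyl group or a chain ending in a carboxylic acid on this nitrogen would also stay within the scatter in these two assays. Going by these compounds, whether the same exchange reads alike on a different core also stays open.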